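This account rests on a few compounds, and the source may have more. Where it says the series, first, only, none or still open, it means among the compounds named here.

Two compounds share a core and are separated only by the group on one aromatic carbon. Compound 1 `FC(F)(F)c1ccc(-c2ccc3c(NCCCNCc4ccco4)ccnc3c2)cc1` carries a 4-(trifluoromethyl)phenyl there, and in a physicochemical assay for acid dissociation, compound 1 gives 9.47. Compound 2 `COc1ccccc1Oc1ccc2c(NCCCNCc3ccco3)ccnc2c1` carries a 2-methoxyphenoxy instead, and in this assay compound 2 gives 9.28. The change between them, 2-methoxyphenoxy in place of 4-(trifluoromethyl)phenyl on an aromatic carbon, comes with a number 0.19 log units lower from compound 1 to compound 2 (within the scatter), so on the numbers shown compound 2 stands together with compound 1 rather than apart from it.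

Compound 3 `COc1ccc(Oc2ccc3c(NCCCNCc4ccco4)ccnc3c2)cc1` keeps the same atoms as compound 2, joined differently: 4-methoxyphenyl in place of 2-methoxyphenyl on an oxygen on an aromatic ring. Among the measured compounds shown here, the only measured step, a replacement of the whole group on the aromatic carbon, stayed within the scatter, and the present rearrangement lies further from the amine chain than that one. The expected step in this assay is therefore a number 0.02 log units higher from compound 2 to compound 3 (within the scatter), none beyond the scatter. For compound 3 the estimate in this assay is 9.3, expected to fall between 8.95 and 9.65.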

Compound 3, acid dissociation constant: 9.28
Compound 3: middle estimate off by 0.02 log units, on the high side; low and high end bracket the measured number.
By their numbers in this assay, from the lowest: compounds 2, 3 and 1 (each within the scatter of the next).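

In this assay, among the compounds shown here, 4-methoxyphenyl in place of 2-methoxyphenyl on an oxygen on an aromatic ring comes with no change at the digits printed from compound 2 to compound 3 (within the scatter), which gives the first reading of a rearrangement within the group rather than a replacement of the whole group. The 4-methoxyphenoxy group, set against 4-(trifluoromethyl)phenyl on an aromatic carbon, comes with a number 0.19 log units lower from compound 1 to compound 3 (within the scatter), so all three compounds now stand within the scatter of one another. Nothing available explains why these numbers sit together.

On these data alone, all three groups at this place carry an aromatic ring, so it remains open whether a primary amine or a carboxylic acid there would shift the number beyond the scatter. As far as these compounds go, whether a longer chain in place of the amine chain would do so is equally open.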